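The compounds below may be only part of what the source reports. "The series", "measured", "known", "first", "only" and "open" are said of these compounds alone.

Within the data shown here, compound 2, `N#C/C(=C\c1ccccc1OS(=O)(=O)c1ccc(F)cc1)C(=O)Nc1nnc(Cc2ccccc2)s1`, is one of two compounds measured in a functional assay on HL-60 cells (Homo sapiens) for inhibition, read by CCK-8 assay, with a stated time of 48 h, tested at 20 uM; a higher number here means more inhibition of growth at the concentration tested, a lower number less inhibition of growth; in this assay compound 2 gives 22%. Among the measured compounds shown here, its only measured neighbour, compound 1, `Cc1ccc(S(=O)(=O)Oc2ccccc2/C=C(\C#N)C(=O)Nc2nnc(Cc3ccccc3)s2)cc1`, gives 16% in this assay, and the two numbers lie within the usual scatter of each other. For the measured compounds named here, the one step recorded between them, a number 6 percentage points higher from compound 1 to compound 2 (within the scatter), comes from fluoro in place of methyl on an aromatic carbon, a change on a different part of the structure from the one now in question. Compound 3, `N#C/C(=C\c1ccccc1OS(=O)(=O)c1ccc(F)cc1)C(=O)Nc1nnc(Cc2cccc(F)c2)s1`, differs from compound 2 by fluoro in place of hydrogen on an aromatic carbon. Going by the values given here, no measured step touches the benzyl group, so the measured step bears on it only loosely, and it was itself within the scatter. A step of a number 2 percentage points higher from compound 2 to compound 3 (within the scatter) in this assay is therefore expected, with no movement beyond the scatter in either direction. Compound 3 is accordingly estimated at 24% in this assay, within a range of 12% to 36%.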

Compound 3, percent growth inhibition at one concentration: 22%
Compound 3: middle estimate off by 2 percentage points, on the high side; the measured number falls inside the stated range.
By their numbers in this assay, from the lowest: compounds 1, 2 and 3 (each within the scatter of the next).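

In this assay, among these compounds, the step on the benzyl group, from benzyl to 3-fluorobenzyl, reads as no change at the digits printed from compound 2 to compound 3 (within the scatter) and is the first measured change at this part of the structure. It shows that fluoro in place of hydrogen on this six-membered aromatic ring, meta to a large group, does not move growth inhibition beyond the scatter, something the earlier step on the other aromatic ring could not show. No evidence is available to explain this result.

Going by these compounds, whether a methoxy group, an amine or a carboxylic acid on this ring would move the number beyond the scatter remains open. So does the effect of replacing the benzyl group with a longer chain, such as phenethyl.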